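The source may hold more compounds than are shown below. What is called first, only, known or untested is meant among the compounds shown, and "the series" means these compounds.

Of the compounds shown here, three built on one shared core have been tested in an assay on isolated protein for inhibition of Voltage-dependent L-type calcium channel subunit alpha-1C (Cavia porcellus); a lower number here means a stronger inhibitor, a higher number a weaker inhibitor. Compound 1, `CCOC(=O)C1=C(C)NC(C)=C(C(=O)OCC)C1c1[nH]cnc1Cl`, carries two ethyl esters and gives 437 nM, the highest of the three numbers. Compound 2, `CC1=C(C(=O)OC2CCCC2)C(c2[nH]cnc2Cl)C(C(=O)OC2CCCC2)=C(C)N1`, with cyclopentyl esters in their place, gives 97.7 nM, a lower number than compound 1 by more than the usual scatter. Compound 3, `CC1=C(C(=O)OCCc2ccccc2)C(c2nc[nH]c2Cl)C(C(=O)OCCc2ccccc2)=C(C)N1`, with phenylethyl esters, gives 0.182 nM, far lower again. Across these three, the cyclopentyl and phenylethyl esters go with the lower numbers, though only three points support this and no single-change pairs among them exist.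

Compound 4, `CCOC(=O)C1=C(C)NC(C)=C(C(=O)OC(C)(C)C)C1c1[nH]cnc1Cl`, changes one of the two esters of compound 1: tert-butyl in place of ethyl on an oxygen next to a carbonyl group. The other ethyl ester stays as it is. Since compound 1 to compound 2 and compound 1 to compound 3 both show lower numbers with larger esters, the expectation for compound 4 is a lower number than compound 1 in this assay, by a step of moderate size, a 2.9-fold lower number from compound 1 to compound 4 (0.46 log units; beyond the scatter), beyond the scatter but smaller than the gap to compound 2, with only one of the two esters altered. The estimate for compound 4 is 150 nM, within the range 40 nM to 500 nM.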

Compound 4, half-maximal inhibitory concentration: 1660 nM
Compound 4: middle estimate off by 11-fold (1.04 log units), on the low side, outside the stated range (above it).
By their numbers in this assay, from the lowest: compound 3; then compound 2; then compound 1; then compound 4.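

In this assay, putting tert-butyl in place of ethyl on an oxygen next to a carbonyl group, in just one of the two esters, gives a 3.8-fold higher number from compound 1 to compound 4 (0.58 log units; beyond the scatter) and this modest step lies beyond the usual scatter. A larger group at this place therefore does not by itself go with a lower number: compound 4 goes against the trend suggested by compound 2 and compound 3, whose two esters both differ from those of compound 1, so neither gives a single-change comparison. No measurement available here explains the rise.

The compounds shown leave open whether the higher number belongs to tert-butyl in particular or to branched esters more widely, a question that an isopropyl ester in the same place would help to answer. Also open, going by these compounds, is how a single cyclopentyl or phenylethyl ester would behave with the other ethyl ester kept, as the lower numbers of compound 2 and compound 3 come with both esters changed at once.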